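This account rests on a few compounds, and the source may have more. Where it says the series, first, only, none or still open, it means among the compounds named here.

Working notes on the series in a functional assay on PANC-1 cells (Homo sapiens) for inhibition, read by MTT assay, with a stated time of 24 h, tested at 10 uM; a higher number here means more inhibition at the concentration tested (going by the name of the read-out), a lower number less inhibition.

Compound 1 `CC(C)=CCC1Cc2c(OCCCNC(=O)c3cccs3)cc(=O)n(CCCO)c2CC1(C)C` gives 33.6% in this assay, the lowest of the three numbers in hand. Compound 2 `CC(C)=CCC1Cc2c(OCCCNC(=O)c3ccc([N+](=O)[O-])cc3)cc(=O)n(CCCO)c2CC1(C)C` gives 49.9%, and compound 3 `COc1ccc(OCCCOc2cc(=O)n(CCCO)c3c2CC(CC=C(C)C)C(C)(C)C3)cc1` gives 47.7%; the difference a number 2.2 percentage points lower from compound 2 to compound 3 (within the scatter) is within the scatter, so these two are not ordered against each other.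

Both measured steps leave compound 1 and move upward: a number 16.3 percentage points higher from compound 1 to compound 2 (beyond the scatter) and a number 14.1 percentage points higher from compound 1 to compound 3 (beyond the scatter). Each is modest but beyond the scatter, and each alters the same side chain on the aromatic oxygen of the shared core.

Compound 4 `CC(C)=CCC1Cc2c(OC(=O)Nc3cccc(F)c3)cc(=O)n(CCCO)c2CC1(C)C` changes that same position again: (3-fluorophenyl)carbamoyl in place of 3-(((thiophen-2-yl)carbonyl)amino)propyl on an oxygen on an aromatic ring. Going by the values given here, neither measured step is a close model for it, since the propyl chain is removed and a carbamoyl is attached directly to the aromatic oxygen; the 3-fluorophenyl has no counterpart among compounds 2 and 3. What the two measured steps do show is that every change so far at this position raised the number from compound 1 by a modest amount, so a modest upward step is the working expectation, with wide uncertainty.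

Compound 4 is therefore expected to give 43%, within 27% to 59%, corresponding to an estimated step of a number 9.4 percentage points higher from compound 1 to compound 4 (within the scatter).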

Compound 4, a percentage reported as inhibition, at one concentration (the size of the read-out at that concentration, not a potency): 66.1%
Compound 4: middle estimate off by 23.1 percentage points, on the low side, outside the stated range (above it).
By their numbers in this assay, from the lowest: compound 1; then compounds 3 and 2 (each within the scatter of the next); then compound 4.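

In this assay, the step of a number 32.5 percentage points higher from compound 1 to compound 4 (beyond the scatter) is printed as large, whereas the steps of a number 16.3 percentage points higher from compound 1 to compound 2 (beyond the scatter) and a number 14.1 percentage points higher from compound 1 to compound 3 (beyond the scatter) are printed as modest. The change at this position therefore need not keep the propyl chain: with (3-fluorophenyl)carbamoyl on the oxygen on an aromatic ring, compound 4 has the highest number of the four, and compounds 2 and 3 both fall short of it on their printed values. Nothing measured here accounts for the size of this step.

This change replaces the propyl chain, the amide link and the thiophen-2-yl ring in one move, so the shares of the carbamoyl link, the phenyl ring and the fluorine remain unseparated. An unsubstituted phenylcarbamoyl, a 3-chlorophenylcarbamoyl or a thiophen-2-ylcarbamoyl on the same oxygen would begin to divide these shares, while the single tested concentration leaves the potency of compound 4 open.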